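The source may report more compounds than this note shows. Statements on the series, on what has been measured and on what is new or still open speak of the compounds shown alone.

Compound 1 `CCC(C)n1nc(C)cc1NC(=O)Cn1nnc(-c2ccccc2)n1`: in an assay on HEK293 cells for activation of Kir3.1/Kir3.2 (Homo sapiens), read by thallium flux (on this read-out lower numbers stand for an effect already at smaller amounts and higher numbers for an effect only at larger amounts of compound), compound 1 gives > 5000 nM, which is a limit of the assay rather than a number.
Compound 2 `Cc1nc(NC(=O)Cn2nnc(-c3ccccc3)n2)n(-c2ccccc2)n1`: compound 2 is reported as "not active" (no number reported).
Compound 3 `Cc1cc(NC(=O)Cn2nnc(-c3cccc(Cl)c3)n2)n(C2CCCCC2)n1`: compound 3 gives 300 nM.

For the measured compounds named here, compound 3 therefore stands as the only member of the set with a numerical value in this assay; the other two entries are a limit of > 5000 nM in this assay, at which 1 of the 3 values shown sits, and an entry without a number. Going by the values given here, no step between two measured compounds is available, so the effect of altering the aryl group has not been observed directly.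

Compound 4 `Cc1cc(NC(=O)Cn2nnc(-c3ccc(F)c(F)c3)n2)n(C2CCCCC2)n1` differs from compound 3 by 3,4-difluorophenyl in place of 3-chlorophenyl on an aromatic carbon. Among the compounds with values here, since both groups are small halogenated aryl rings and no measured step informs the change, the author expects a step of a 1.7-fold higher number from compound 3 to compound 4 (0.22 log units; within the scatter) that stays within the scatter or leans slightly weaker. Compound 4 is estimated at 500 nM, in the range 150 nM to 2000 nM.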

Compound 4, half-maximal effective concentration: 116 nM
The estimate for compound 4 lay 4.3-fold (0.63 log units) above the measured number; the measured number lies below the stated range.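

Exchanging 3-chlorophenyl for 3,4-difluorophenyl on the aromatic carbon of the five-membered ring gives a 2.6-fold lower number from compound 3 to compound 4 (0.41 log units; beyond the scatter) in this assay and is the only step shown at this position. The number there therefore responds to the substitution on the aryl ring, and a lower number is reached with two fluorines in place of one chlorine. Nothing shown accounts for this step.

This single step does not separate the loss of the chlorine from the addition of the fluorines. Going by these compounds, whether a methoxy group or an amine on that aryl ring would keep the number this low remains open.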